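Butylamino for pentyloxy, starting from a limit

The source may hold more compounds than are shown below. What is called first, only, known or untested is meant among the compounds shown, and "the series" means these compounds.

Measured in an ADME assay on BCBL1 cells (Homo sapiens) for cytotoxicity, with a stated time of 7 days; a higher number here means that more compound is tolerated, a lower number that less compound is tolerated:
compound 1 `Nc1nc(OCc2ccccc2)c2ncn(/C=C3/CC3(CO)CO)c2n1`: > 20000 nM (a limit)
compound 2 `CCCCCOc1nc(N)nc2c1ncn2/C=C1/CC1(CO)CO`: > 20000 nM (a limit)

Compound 2 gives only a limit (> 20000 nM). Compound 3 `CCCCNc1nc(N)nc2c1ncn2/C=C1/CC1(CO)CO` differs from it by butylamino in place of pentyloxy on an aromatic carbon and so carries butylamino in place of pentyloxy on an aromatic carbon. Among the compounds with values here, the one measured step (a step that the two limits leave unreadable from compound 1 to compound 2) has no readable size. The evidence is the limit of > 20000 nM in this assay, at which 2 of the 2 values shown sit, and offers no measured size to carry over. The expected step is a number no higher from compound 2 to compound 3 (the limit leaves the size open) in this assay (no expected change beyond the scatter). Compound 3 is estimated at 20000 nM (expected range 9000 nM to 40000 nM).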

Compound 3, half-maximal cytotoxic concentration: > 20000 nM
Compound 3: no number, only a limit; the forecaster's own chance of this, stated with the estimate: 70%; the middle value lies on the limit itself.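

Compound 1, compound 2 and compound 3 each give only a limit in this assay, so no step among them can be read: the limit of > 20000 nM in this assay, at which 3 of the 3 values shown sit.

On these data alone, whether benzyloxy, pentyloxy and butylamino differ at all in this read-out stays open.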